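Methoxy for methyl on the pendant phenyl of compound 3

A few compounds are considered here, and "the series" means these few. Any claim that something is new, unique, unknown or untested is made for them only; others in the source may bear on it.

Compound 1 `COc1ccc(-c2cn(/N=C/c3cc4ccccc4nc3Cl)c(N)n2)cc1` gives 12400 nM in an ADME assay on HUVEC cells (Homo sapiens) for cytotoxicity, read by MTT assay, with a stated time of 48 h; a lower number here means a stronger inhibitor, a higher number a weaker inhibitor.
Compound 2 `Cc1ccc2nc(Cl)c(/C=N/n3cc(-c4ccccc4)nc3N)cc2c1` gives 41500 nM in this assay.
Compound 3 `Cc1ccc(-c2cn(/N=C/c3cc4cc(C)ccc4nc3Cl)c(N)n2)cc1` gives 18000 nM in this assay.

Compound 3 stands second highest of the three numbers. Its nearest neighbour is compound 1, whose number is lower but within the scatter; its furthest is compound 2, and the step of a 2.3-fold lower number from compound 2 to compound 3 (0.36 log units; beyond the scatter) is beyond the scatter, arising from methyl in place of hydrogen on an aromatic carbon.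

Compound 4 `COc1ccc(-c2cn(/N=C/c3cc4cc(C)ccc4nc3Cl)c(N)n2)cc1` has not yet been measured. It differs from compound 3 by methoxy in place of methyl on an aromatic carbon, the group sitting on an aromatic carbon of a six-membered aromatic ring of carbon only, para to a large group. Among the compounds with values here, no measured step matches this change: compound 1 and compound 2 also carry a methoxyphenyl and a phenyl, but they differ from each other in two places, so only their two values can be compared, and they lie beyond the scatter apart. Within the data shown here, the one measured step, from compound 2 to compound 3, concerns the other ring and is modest.

Among the measured compounds shown here, with no step bearing directly on the methyl-to-methoxy change, compound 4 is expected to lie close to compound 3, with a step of a 1.3-fold lower number from compound 3 to compound 4 (0.11 log units; within the scatter) that is not expected to exceed the scatter. The estimate for compound 4 is 14000 nM, between 7000 nM and 28000 nM.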

Compound 4, half-maximal inhibitory concentration: 12200 nM
Compound 4: the middle estimate sits 1.1-fold (0.06 log units) above what was measured; low and high end bracket the measured number.
By their numbers in this assay, from the lowest: compounds 4, 1 and 3 (each within the scatter of the next); then compound 2.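

With methoxy now measured at this place, on an aromatic carbon of a six-membered aromatic ring of carbon only, para to a large group, this assay does not separate the 4-methylphenyl and 4-methoxyphenyl compounds, with a 1.5-fold lower number from compound 3 to compound 4 (0.17 log units; within the scatter). Either group carries a lower number than hydrogen at this place, since methoxy in place of hydrogen gives a 3.4-fold lower number from compound 2 to compound 4 (0.53 log units; beyond the scatter), a larger step than the one printed for methyl, a 2.3-fold lower number from compound 2 to compound 3 (0.36 log units; beyond the scatter). Methyl in place of hydrogen now also has a second reading, a 1.0-fold lower number from compound 1 to compound 4 (0.01 log units; within the scatter), and the two readings do not differ beyond what two such steps can scatter: the same change on two cores in this assay, a 2.3-fold lower number (0.36 log units; beyond the scatter) from compound 2 to compound 3 and a 1.0-fold lower number (0.01 log units; within the scatter) from compound 1 to compound 4, 2.3-fold (0.36 log units) apart, within the scatter of two such steps.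

The compounds shown leave open whether an amine or a carboxylic acid at this place would fall with methyl and methoxy or with hydrogen. They also leave open whether a longer chain, such as ethoxy, would lower the number any further.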